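Chloro added to the phenyl: compound 3 to compound 4

A few compounds are considered here, and "the series" means these few. Any claim that something is new, unique, unknown or untested is made for them only; others in the source may bear on it.

Measured in a functional assay on DU-145 cells (Homo sapiens) for cytotoxicity, read by MTT assay, with a stated time of 48 h; a higher number here means a weaker inhibitor, a lower number a stronger inhibitor:
compound 1 `CCOC(=O)c1c(-c2cc3ccccc3oc2=O)nn(-c2ccccc2)c1C(=O)OCC` gives 57000 nM
compound 2 `COC(=O)c1c(-c2cc3ccccc3oc2=O)nn(-c2cccc(Cl)c2)c1C(=O)OC` gives 32000 nM
compound 3 `CCOC(=O)c1c(-c2cc3cc(OC)ccc3oc2=O)nn(-c2ccccc2)c1C(=O)OCC` gives 27000 nM

Compound 3 carries the lowest of the three numbers in this assay; its step from compound 1, a 2.1-fold lower number from compound 1 to compound 3 (0.32 log units; beyond the scatter), is beyond the scatter, whereas compound 2 lies within the scatter of compound 3. Compound 4 `CCOC(=O)c1c(-c2cc3cc(OC)ccc3oc2=O)nn(-c2cccc(Cl)c2)c1C(=O)OCC` differs from compound 3 by chloro in place of hydrogen on an aromatic carbon. Within the data shown here, no measured pair differs only in this way; compound 1 and compound 2 differ in both the chloro and the ester, and their two values show the lower number for compound 2. The step to compound 4 is therefore expected to be small, probably within the scatter, if anything toward a lower number: a 1.2-fold lower number from compound 3 to compound 4 (0.09 log units; within the scatter). Compound 4 is estimated at 22000 nM, in the range 10000 nM to 45000 nM.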

Compound 4, half-maximal inhibitory concentration: 29000 nM
Beside the measured number, compound 4's estimate is 1.3-fold (0.12 log units) below it; the measured number falls inside the stated range.
By their numbers in this assay, from the lowest: compounds 3, 4, 2 and 1 (each within the scatter of the next, the first and the last beyond it).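

In this assay, among these compounds, this is the first reading of phenyl to 3-chlorophenyl with nothing else changed: the step of a 1.1-fold higher number from compound 3 to compound 4 (0.03 log units; within the scatter) shows that, with the methoxy and the ethyl esters in place, chloro at this position of the phenyl leaves the two compounds within the scatter of each other. No measurement available accounts for this result.

As far as these compounds go, whether an amine or a carboxylic acid at this position would separate from hydrogen remains open. So does whether chloro behaves the same way on the core lacking the methoxy.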